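The compounds below may be only part of what the source reports. "The series", "measured", "known", "first", "only" and "open" are said of these compounds alone.

Measured so far in a functional assay on cells (Platelet, Homo sapiens) for inhibition; on this read-out higher numbers stand for weaker inhibition and lower numbers for stronger inhibition:
- compound 1 `CCOC(=O)c1ccc(-c2nn(Cc3ccccc3OC)c3ccccc23)cc1`: > 10000 nM, a limit
- compound 2 `CCOC(=O)c1ccc(-c2nn(Cc3cccc(OC)c3)c3ccccc23)cc1`: > 10000 nM, a limit

Compound 2 stands at a limit, > 10000 nM. Compound 3 `CCOC(=O)c1ccc(-c2nn(CC)c3ccccc23)cc1` differs from it as follows: methyl in place of 3-methoxyphenyl on a saturated chain carbon bound to an aromatic nitrogen. Among the measured compounds shown here, the only measured step is a step that the two limits leave unreadable from compound 1 to compound 2, and it offers no size to carry over. The evidence is simply (the limit of > 10000 nM in this assay, at which 2 of the 2 values shown sit). For the measured compounds named here, no step of known size or direction is therefore expected in this assay, only continued weak inhibition. The expected move is a step that the limit leaves unreadable from compound 2 to compound 3. For compound 3 the estimate is 15000 nM, with an expected range from 5000 nM to 50000 nM.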

Compound 3, half-maximal inhibitory concentration: > 10000 nM
Compound 3 ended at the assay's limit; the forecaster's own chance of this, stated with the estimate: 80%; the middle value does not contradict the limit.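

In this assay, among the compounds shown here, compound 3 sits at the same limit as compound 1 and compound 2, so no step among them can be read. The compounds shown leave open which group, if any, on the saturated chain carbon bound to an aromatic nitrogen would give a measurable value.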